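Swapping the bicyclic ring for a smaller pyrazole

The compounds below may be only part of what the source reports. "The series", "measured", "known", "first", "only" and "open" are said of these compounds alone.

Measured so far:
Compound 1 `Cc1nc(C(F)(F)F)ccc1C(=O)Nc1ccc(Cl)c(-c2nc3ccccc3n2C)c1`: 9 nM
Compound 2 `Cc1nc(C(F)(F)F)ccc1C(=O)Nc1ccc(Cl)c(-n2cc3ccccc3n2)c1`: 80 nM

Both compounds were tested in an assay on C3H 10T1/2 cells for inhibition of Sonic hedgehog protein (Mus musculus), read by a luciferase reporter; on this read-out higher numbers stand for weaker inhibition and lower numbers for stronger inhibition. Compound 2 gives 80 nM, the highest number of the two measured; its nearest neighbour, compound 1, gives 9 nM. For the measured compounds named here, the only measured step is an 8.9-fold higher number from compound 1 to compound 2 (0.95 log units; beyond the scatter), showing that the ring attached at this position of the shared core matters.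

Compound 3 `Cc1nc(C(F)(F)F)ccc1C(=O)Nc1ccc(Cl)c(-c2ccn(C)n2)c1` differs from compound 2 in that same position: 1-methyl-1H-pyrazol-3-yl in place of 2H-indazol-2-yl on an aromatic carbon. Going by the values given here, no measured step covers this exact change, so the expectation rests only on the single step from compound 1 to compound 2, which shows this position can move the number by a moderate amount in either direction. The estimate for compound 3 in this assay is 40 nM, within 8 nM to 200 nM, meaning an expected step of a 2.0-fold lower number from compound 2 to compound 3 (0.30 log units; within the scatter).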

Compound 3, half-maximal inhibitory concentration: 550 nM
The estimate for compound 3 lay 14-fold (1.14 log units) below the measured number; measured number above the stated range.
By their numbers in this assay, from the lowest: compound 1; then compound 2; then compound 3.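

In this assay the smaller 1-methyl-1H-pyrazol-3-yl, with one five-membered aromatic ring and no six-membered aromatic ring, gives a 6.9-fold higher number from compound 2 to compound 3 (0.84 log units; beyond the scatter) when it takes the place of 2H-indazol-2-yl. Set against 1-methyl-1H-benzimidazol-2-yl, the same group gives a 61-fold higher number from compound 1 to compound 3 (1.79 log units; beyond the scatter) and so, among these three compounds, both groups that carry a six-membered aromatic ring give lower numbers than the lone five-membered ring, with no compound going against this. Nothing measured here says why this change weakens inhibition so strongly.

Still open, on these data alone, is how a phenyl group or a pyridine, each a single six-membered ring, would compare at this position. Also open, as far as these compounds go, is whether the methyl group on the pyrazole has any part in the number.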